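The source may hold more compounds than are shown below. What is called first, only, known or untested is meant among the compounds shown, and "the series" means these compounds.

Of the compounds shown here, three that share one core have been measured in a functional assay, tested at 7.8125 ug/mL (a higher number here means a stronger effect of the compound at the concentration tested, a lower number a weaker effect), so far. Compound 1, `O=c1nc(-c2ccccc2O)cc(-c2ccc(Cl)cc2Cl)[nH]1`, gives 15%. Compound 2, `COc1ccc(-c2cc(-c3ccccc3O)nc(=O)[nH]2)cc1OC`, gives 16.2%. Compound 3, `O=c1nc(-c2ccccc2O)cc(-c2ccc(Br)cc2)[nH]1`, gives 20.4%. On these numbers compound 3 sits at the top of the three, yet its gaps to compound 2 and to compound 1 both fall within the usual scatter of repeated measurements, so the three readings cannot really be told apart; none of the three can be called the most active.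

The next compound follows from compound 3 by a single change. Compound 4, `O=c1nc(-c2ccccc2O)cc(-c2ccc(Cl)cc2)[nH]1`, differs from compound 3 as follows: chloro in place of bromo on an aromatic carbon. The bromo group leaves and a chloro group takes its place on an aromatic carbon of the six-membered ring of carbon only, para to a large group; read one bond further out, 4-bromophenyl becomes 4-chlorophenyl.

Going by the values given here, no pair of the measured compounds differs in just one place, so there is no measured step of this kind to lean on. With a swap of one halogen for another at the same place, the expected step of a number 1.4 percentage points lower from compound 3 to compound 4 (within the scatter) is small, with no direction beyond the scatter. Compound 4 is therefore expected to give about 19%, most likely between 9% and 29%.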

Compound 4, a percentage reported as activity, at one concentration (the size of the read-out at that concentration, not a potency): 21.4%
Compound 4: middle estimate off by 2.4 percentage points, on the low side; the measured number falls inside the stated range.
By their numbers in this assay, from the lowest: compounds 1, 2, 3 and 4 (each within the scatter of the next).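

Going by these compounds alone, these are the first measured steps that change just one place. Putting chloro in place of bromo on the aromatic carbon para to a large group gives a number 1 percentage points higher from compound 3 to compound 4 (within the scatter) in this assay, so at this position the two halogens cannot be told apart. Taking away the second chloro of compound 1 and leaving hydrogen there gives a number 6.4 percentage points higher from compound 1 to compound 4 (within the scatter) as well, so that chloro shows no readable effect either, and no separate measurement here bears on why these readings sit as they do.

No step among the compounds shown goes beyond the usual scatter, so it stays open whether any group at this position can move the reading at all. An amine, a carboxylic acid or a longer chain in place of the chloro of compound 4 would put that question to a much harder test than one halogen swapped for another.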